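Isopropyl on the Hydroxyurea Nitrogen of a Chloro Analogue

This account rests on a few compounds, and the source may have more. Where it says the series, first, only, none or still open, it means among the compounds named here.

Of the compounds shown here, two have been measured in a functional assay for inhibition of Polyunsaturated fatty acid 5-lipoxygenase (Homo sapiens); on this read-out lower numbers stand for an effect already at smaller amounts and higher numbers for an effect only at larger amounts of compound. Compound 1 `CC(C)N(O)C(=O)NCCSc1nc2ccccc2s1` gives 130 nM. Compound 2 `O=C(NO)NCCSc1nc2cc(Cl)ccc2s1` gives 24500 nM, the higher of the two numbers, and its gap to compound 1 lies far beyond the scatter. Compound 3 `CC(C)N(O)C(=O)NCCSc1nc2cc(Cl)ccc2s1` has not yet been measured; it differs from compound 2 by isopropyl in place of hydrogen on an amide-type nitrogen. A large step toward lower numbers is expected, a 120-fold lower number from compound 2 to compound 3 (2.09 log units; beyond the scatter), since compound 1 carries the same isopropyl group and gives 130 nM. Compound 3 is therefore estimated at 200 nM, with a range from 60 nM to 700 nM.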

Compound 3, half-maximal effective concentration: 70 nM
Compound 3: middle estimate off by 2.9-fold (0.46 log units), on the high side, within the range that was stated.
By their numbers in this assay, from the lowest: compounds 3 and 1 (each within the scatter of the next); then compound 2.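

In this assay, isopropyl in place of hydrogen on the amide-type nitrogen gives a 350-fold lower number from compound 2 to compound 3 (2.54 log units; beyond the scatter), so this one position carries a very large step even with chloro present. Chloro in place of hydrogen on an aromatic carbon, with isopropyl kept, gives only a 1.9-fold lower number from compound 1 to compound 3 (0.27 log units; within the scatter), so of these two changes only the isopropyl produces a step beyond the scatter. No measurement here explains why isopropyl has so large an effect.

The compounds shown leave open whether methyl or cyclohexyl on that nitrogen would serve as isopropyl does. They also leave open whether methoxy in place of chloro would stay within the scatter of compound 1.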